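A Second Aryl Group at the Ring Nitrogen of Compound 2

The source may hold more compounds than are shown below. What is called first, only, known or untested is meant among the compounds shown, and "the series" means these compounds.

Compound 1 `CC(C)N1CCN(Cc2csc(N)c2C(=O)c2ccc(Cl)cc2)CC1` and compound 2 `Nc1scc(CN2CCN(c3ccc([N+](=O)[O-])cc3)CC2)c1C(=O)c1ccc(Cl)cc1` share one core and differ only in the group on an amine nitrogen in a ring. In a functional assay on CHO cells with adenosine receptor A1 (Homo sapiens) as the target, read by cAMP accumulation and immunoassay, with a stated time of 6 min, tested at 0.1 uM (on this read-out higher numbers stand for a weaker effect at the one concentration tested and lower numbers for a stronger effect), compound 1 gives 3.6%, while compound 2 gives -13%. Of these two numbers compound 2 stands lowest, and the step of a number 16.6 percentage points lower from compound 1 to compound 2 (beyond the scatter) lies beyond the scatter. Compound 3 `Nc1scc(CN2CCN(c3ccccc3C(F)(F)F)CC2)c1C(=O)c1ccc(Cl)cc1` carries the change (2-(trifluoromethyl)phenyl in place of 4-nitrophenyl on an amine nitrogen in a ring). Among the measured compounds shown here, the one measured step, from isopropyl to 4-nitrophenyl, exchanges a small chain for an aromatic ring, whereas the change to compound 3 exchanges one aromatic ring for another; no measured pair shows what such a swap does, so the only guide is that compound 2 already sits at the low end. The expectation is therefore a step no larger than the scatter, a number 3 percentage points higher from compound 2 to compound 3 (within the scatter). Compound 3 is thus estimated at -10%, within a range from -32% to 14%.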

Compound 3, a percentage reported as activity, at one concentration (the size of the read-out at that concentration, not a potency): -7.5%
Estimate against measurement, compound 3: 2.5 percentage points below, within the range that was stated.
By their numbers in this assay, from the lowest: compounds 2 and 3 (each within the scatter of the next); then compound 1.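

In this assay, exchanging one aromatic ring for another on the ring nitrogen gives a number 5.5 percentage points higher from compound 2 to compound 3 (within the scatter), so 4-nitrophenyl and 2-(trifluoromethyl)phenyl cannot be told apart here, even though the first has 2 hydrogen-bond acceptors and the second has none. A second aromatic group also separates from isopropyl, with a number 11.1 percentage points lower from compound 1 to compound 3 (beyond the scatter), so among these three compounds both aromatic groups stand apart from the small chain, and no compound goes against this. Nothing available explains why the two aromatic groups give matching numbers.

Going by these compounds, what a plain unsubstituted phenyl or a benzyl group would give on this ring nitrogen stays open. So does whether a carboxylic acid on the aromatic ring would leave the number at this level.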